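The source may report more compounds than this note shows. Statements on the series, on what has been measured and on what is new or still open speak of the compounds shown alone.

In a functional assay on MCF7 cells (Homo sapiens) for antiproliferative activity, read by MTT assay (a higher number here means a weaker inhibitor, a lower number a stronger inhibitor), this small series offers little firm ground. Compound 3 `NS(=O)(=O)c1ccc(/N=C2\NC(=O)/C(=C3/C(=O)N(Cc4ccccc4)c4ccccc43)S2)cc1` reads > 200000 nM in this measurement, which is a limit of the assay and not a number. Compound 1 `Cc1ccc2c(c1)/C(=C1/S/C(=N/c3ccc(S(N)(=O)=O)cc3)NC1=O)C(=O)N2` reads > 200000 nM as well, again only a limit. Compound 2 `COc1ccc2c(c1)/C(=C1/S/C(=N/c3ccc(S(N)(=O)=O)cc3)NC1=O)C(=O)N2` alone has a number, 125000 nM in the same measurement. Taken together, the data show the limit of > 200000 nM in this assay, at which 2 of the 3 values shown sit, and no more than that.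

Compound 4 `NS(=O)(=O)c1ccc(/N=C2\NC(=O)/C(=C3/C(=O)Nc4ccccc43)S2)cc1` differs from compound 3 by hydrogen in place of benzyl on an amide-type nitrogen in a ring and so has hydrogen in place of benzyl on an amide-type nitrogen in a ring. Among the measured compounds shown here, the one measured step is an at least 1.6-fold lower number from compound 1 to compound 2 (0.20 log units; that floor lies within the scatter) and its floor lies within the scatter. It concerns a change on an aromatic carbon, so it says little about the benzyl group. More useful is that compound 2 also has that hydrogen and reads 125000 nM in the same measurement. Compound 1 has that hydrogen too and stays at a limit. In this assay only a small move towards a lower number is therefore expected, perhaps none beyond the scatter. The expected step is an at least 1.3-fold lower number from compound 3 to compound 4 (0.12 log units; that floor lies within the scatter) and remains a rough estimate. For compound 4 the estimated value is 150000 nM with an expected range of 60000 nM to 300000 nM in this measurement.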

Compound 4, half-maximal inhibitory concentration: > 200000 nM
Compound 4 gave a limit, no number; the forecaster's own chance of this, stated with the estimate: 45%; middle value at least 1.3-fold (0.12 log units) away from the limit.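

In this assay, putting hydrogen in place of benzyl on the amide-type nitrogen in a ring does not lift the compound out of the limit, so this change produces no measurable number. Among the compounds shown here, neither the step from compound 3 to compound 4 nor the one from compound 1 to compound 4 can be read, as both pairs consist of two limits. The one readable comparison concerns the aromatic carbon, where hydrogen in place of methoxy gives an at least 1.6-fold higher number from compound 2 to compound 4 (0.20 log units; that floor lies within the scatter), so compound 2 remains the only compound with a number, but this comparison does not establish a real difference, and the series as a whole stays at the edge of what the assay can report: the limit of > 200000 nM in this assay, at which 3 of the 4 values shown sit.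

From the compounds shown here alone, whether benzyl has any effect on this nitrogen remains open, as does whether a smaller group such as ethyl or a longer chain such as propyl would give a number there. Going by these compounds, it is equally open whether an amine or a carboxylic acid on the aromatic carbon would move the value further than methoxy does.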